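Swapping trifluoromethyl for 4-chlorophenyl on a shared core

A few compounds are considered here, and "the series" means these few. Any claim that something is new, unique, unknown or untested is made for them only; others in the source may bear on it.

Compound 1 `Cc1[nH]n(-c2nc3ccccc3n2C)c(=O)c1C` gives > 10000 nM in an assay on isolated protein for inhibition of alpha-ketoglutarate-dependent dioxygenase alkB homolog 3 (Homo sapiens), read by polymerase chain reaction, with a stated time of 1 h (a lower number here means a stronger inhibitor, a higher number a weaker inhibitor), which is a limit of the assay rather than a number. Compound 2 `Cc1[nH]n(-c2nc3cc(C(F)(F)F)ccc3[nH]2)c(=O)c1Cc1ccccc1` gives 610 nM. Compound 3 `Cc1[nH]n(-c2nc3ccccc3[nH]2)c(=O)c1Cc1ccc(F)cc1` gives 600 nM.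

Among the two measured numbers, compound 2 holds the higher one, but compound 2 and compound 3 sit within the usual scatter of each other, so no order between them can be claimed. Compound 4 `Cc1[nH]n(-c2nc3cc(-c4ccc(Cl)cc4)ccc3[nH]2)c(=O)c1Cc1ccccc1` differs from compound 2 in one place: 4-chlorophenyl in place of trifluoromethyl on an aromatic carbon. For the measured compounds named here, no measured pair shows this change, so its effect is unknown. The expected step from compound 2 to compound 4 is a 1.5-fold lower number from compound 2 to compound 4 (0.18 log units; within the scatter), a small improvement that may not exceed the scatter. Compound 4 is therefore estimated at 400 nM, between 100 nM and 2000 nM.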

Compound 4, half-maximal inhibitory concentration: 1500 nM
Compound 4: middle estimate off by 3.8-fold (0.57 log units), on the low side, within the range that was stated.
By their numbers in this assay, from the lowest: compounds 3 and 2 (each within the scatter of the next); then compound 4. At a limit, above all of these: compound 1.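

For the compounds shown here, this is the first measured change at this aromatic carbon of the shared core: in this assay, 4-chlorophenyl in place of trifluoromethyl gives a 2.5-fold higher number from compound 2 to compound 4 (0.39 log units; beyond the scatter). The added aromatic ring of carbon only therefore brings a weaker result here, not a stronger one, though the step is modest. Nothing measured among these compounds accounts for the step.

From the compounds shown here alone, whether an amine or a carboxylic acid on this carbon would give a lower number stays open. So does whether plain phenyl, without the chlorine, would behave like 4-chlorophenyl.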